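The source may hold more compounds than are shown below. What is called first, only, known or untested is meant among the compounds shown, and "the series" means these compounds.

Compounds measured in a functional assay on MDA-MB-231 cells (Homo sapiens) for cytotoxicity, read by MTT assay, with a stated time of 72 h; on this read-out higher numbers stand for weaker inhibition and lower numbers for stronger inhibition:

Compound 1 `CC1CCN(Cc2ccc3nc(NC(=O)N/N=C/c4cn(Cc5cccc(Cl)c5)c5ccccc45)sc3c2)CC1` gives 2110 nM.
Compound 2 `CC1CCN(Cc2ccc3nc(NC(=O)N/N=C/c4c[nH]c5ccccc45)sc3c2)CC1` gives 2460 nM.

Compound 1 stands at the lowest of the two numbers, but its nearest neighbour, compound 2, lies within the scatter: the pair differs by a 1.2-fold higher number from compound 1 to compound 2 (0.07 log units; within the scatter), so neither can be called the stronger. Compound 3 `CN(C)Cc1ccc2nc(NC(=O)N/N=C/c3cn(Cc4cccc(Cl)c4)c4ccccc34)sc2c1` has not been measured in this assay. It differs from compound 1 by dimethylamino in place of 4-methylpiperidin-1-yl on a saturated chain carbon bound to an aromatic carbon. Within the data shown here, no measured step touches this position: the only step on record, from compound 1 to compound 2, concerns the aromatic nitrogen and was within the scatter. The data therefore offer no ground for expecting a step beyond the scatter in either direction, and the estimate is anchored on compound 1 with a broad range to reflect this. Compound 3 is expected to give about 2500 nM, between 1000 nM and 6500 nM, a step of a 1.2-fold higher number from compound 1 to compound 3 (0.07 log units; within the scatter).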

Compound 3, half-maximal inhibitory concentration: 1140 nM
For compound 3 the middle estimate is 2.2-fold (0.34 log units) above the measured one; the measured number falls inside the stated range.
By their numbers in this assay, from the lowest: compounds 3, 1 and 2 (each within the scatter of the next, the first and the last beyond it).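

The step at this position reads a 1.9-fold lower number from compound 1 to compound 3 (0.27 log units; within the scatter) in this assay. Among these compounds, it shows that the 4-methylpiperidin-1-yl group, with its six-membered ring and 7 heavy atoms, can give way to dimethylamino, with no ring and 3 heavy atoms, and the number stays within the scatter; until now, the only step on record concerned the aromatic nitrogen. Nothing available gives a reason for this outcome.

The compounds shown leave open whether this position would stay as undisturbed with a morpholin-4-yl group, a primary amine or a carboxylic acid on the same carbon. They also leave open how a longer chain between the core and the dimethylamino nitrogen would read in this assay.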